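Swapping an amino for a methyl on a diaminopyrimidine scaffold

A few compounds are considered here, and "the series" means these few. Any claim that something is new, unique, unknown or untested is made for them only; others in the source may bear on it.

Measured so far in an ADME assay on microsomes from liver (Rattus norvegicus), read by LC-MS, using NADPH, with a stated time of 30 min, tested at 1 uM; a lower number here means that less of the compound is left, a higher number that more of the compound is left:
compound 1 `Cc1nc(N)nc(N[C@@H](C)c2cc3ccc(F)cn3c(=O)c2-c2ccccc2)c1C#N`: 41%
compound 2 `Cc1c([C@H](C)Nc2nc(N)nc(N)c2C#N)c(-c2ccccc2)c(=O)n2cc(F)ccc12`: 85%
compound 3 `C[C@H](Nc1nc(N)nc(N)c1C#N)c1c(-c2ccccc2)c(=O)n2cc(F)ccc2c1C1CC1`: 84%

Compound 2 gives the highest number of the three in this assay, though compound 3 sits within the scatter of it: the change a number 1 percentage points lower from compound 2 to compound 3 (within the scatter) is too small to count. Compound 1 gives a number far lower than compound 2, but the two structures differ in more than one place, so no single step can be read from that pair.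

The new compound 4 `Cc1nc(N)nc(N[C@@H](C)c2c(-c3ccccc3)c(=O)n3cc(F)ccc3c2C)c1C#N` arises from compound 2 by one change: methyl in place of amino on an aromatic carbon. For the measured compounds named here, none of the measured steps covers exactly this swap, so the expectation rests on indirect ground. Going by the values given here, compound 1 is the only measured compound that carries the 2-amino-5-cyano-6-methylpyrimidin-4-yl, and it gives a markedly lower number than the two compounds with the 2,6-diamino-5-cyanopyrimidin-4-yl. For compound 4 a fall is therefore expected, because compound 1 gives 41%. The estimated step from compound 2 is a number 30 percentage points lower from compound 2 to compound 4 (beyond the scatter). Compound 4 is thus expected at 55%, with a range from 30% to 80%.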

Compound 4, percent of the compound remaining: 91%
Compound 4: middle estimate off by 36 percentage points, on the low side; the measured number lies above the stated range.
By their numbers in this assay, from the lowest: compound 1; then compounds 3, 2 and 4 (each within the scatter of the next).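

In this assay, methyl in place of amino on this aromatic carbon gives a number 6 percentage points higher from compound 2 to compound 4 (within the scatter), so with this core the two groups cannot be told apart at this position, and the 2-amino-5-cyano-6-methylpyrimidin-4-yl does not by itself go with a low number. The low number of compound 1 is therefore not a feature of that pyrimidine alone: the one-place comparison on the other side of the molecule, adding a methyl to a carbon of the core, gives a number 50 percentage points higher from compound 1 to compound 4 (beyond the scatter), which makes that core carbon the place where the large difference appears among these compounds. Nothing measured here says why either step has the size it has.

The compounds shown leave open whether hydrogen on that core carbon would give a similarly large step when the 2,6-diamino-5-cyanopyrimidin-4-yl is present, since that pairing does not stand among them. They also leave open whether the tolerance seen for amino and methyl on the pyrimidine extends to other groups there, such as a methoxy group, a chlorine atom or a longer chain like propyl.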